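The source may report more compounds than this note shows. Statements on the series, on what has been measured and on what is new or still open speak of the compounds shown alone.

Working notes on the series

Compound 1 `CCCCN(CC)c1cc(C)nc2c1NC(=O)CN2c1ccc(C#N)cc1C` gives 3.3 nM in an assay on frontal cortex for displacement of a labelled ligand from corticotropin-releasing factor receptor 1 (Rattus norvegicus); on this read-out lower numbers stand for stronger inhibition and higher numbers for weaker inhibition. Compound 3 `CCCCN(CC)c1cc(C)nc2c1NC(=O)CN2c1ccc(C(C)=O)cc1C` carries acetyl in place of cyano on an aromatic carbon on the same core and gives 5.8 nM, a step of a 1.8-fold higher number from compound 1 to compound 3 (0.24 log units; within the scatter). Compound 2 `CCCCN(CC)c1nc(C)nc2c1NCCN2c1ccc(C#N)cc1C` rests on a different core; the difference between the two cores is not broken down here. In this assay compound 2 gives 102 nM, the highest number of the three measured.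

Compound 4 `CCCCN(CC)c1nc(C)nc2c1NCCN2c1ccc(C(C)=O)cc1C` carries the same change on the core of compound 2, namely (acetyl in place of cyano on an aromatic carbon). The surroundings of the place are described in the same words for both pairs, so the change is taken as the same. Within the data shown here, only one measured example of it exists, so the expectation rests on that single step. For compound 4 a step of about a 1.8-fold higher number from compound 2 to compound 4 (0.25 log units; within the scatter) is expected, similar in size to the measured step between compound 1 and compound 3. The estimated value for compound 4 is 180 nM, with a likely span from 70 nM to 450 nM.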

Compound 4, half-maximal inhibitory concentration: 172 nM
For compound 4 the middle estimate is 1.0-fold (0.02 log units) above the measured one, and the stated range covers the measured number.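

In this assay the exchange of cyano for acetyl gives a 1.7-fold higher number from compound 2 to compound 4 (0.23 log units; within the scatter), and the step carries over from one core to the other: the same change on two cores in this assay, a 1.8-fold higher number (0.24 log units; within the scatter) from compound 1 to compound 3 and a 1.7-fold higher number (0.23 log units; within the scatter) from compound 2 to compound 4, 1.0-fold (0.02 log units) apart, within the scatter of two such steps. On both cores the exchange leaves the number within the scatter, so cyano and acetyl cannot be told apart on either core in these pairs. Two pairs do not show that the step would carry over to a further core, nor do they show that any other change would carry over between these two.

Open, from the compounds shown here alone, is whether an amine or a carboxylic acid in place of cyano would also carry over between the two cores. Also open, going by these compounds, is whether a chlorine in place of the methyl group on that ring would do so.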